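The source may report more compounds than this note shows. Statements on the series, on what has been measured and on what is new or still open speak of the compounds shown alone.

Compound 2 `NC(=O)c1cc(-c2ccc(NS(=O)(=O)c3cccc(Cl)c3Cl)cc2)nc2[nH]ncc12` gives 1 nM in an assay for inhibition of serine/threonine-protein kinase Sgk1 (Homo sapiens), with stated times of 30 min and 60 min, in the presence of a further agent that is not named here (a higher number here means a weaker inhibitor, a lower number a stronger inhibitor), and compound 1 `O=C(NC1CCN(CC2CC2)C1)c1cc(-c2ccc(NS(=O)(=O)c3cccc(Cl)c3Cl)cc2)nc2[nH]ncc12` gives 1 nM in this assay, so compound 2 stands level with compound 1 within the scatter. Among the compounds with values here, the only step measured so far runs no change at the digits printed from compound 1 to compound 2 (within the scatter), where hydrogen replaces 1-(cyclopropylmethyl)pyrrolidin-3-yl on the amide-type nitrogen: the whole group leaves and the read-out stays put. Compound 3 `CNC(=O)c1cc(-c2ccc(NS(=O)(=O)c3cccc(Cl)c3Cl)cc2)nc2[nH]ncc12` is the next to be measured. It differs from compound 2 by methyl in place of hydrogen on an amide-type nitrogen, a change at the same amide-type nitrogen that takes carbamoyl to methylcarbamoyl. Because the step of no change at the digits printed from compound 1 to compound 2 (within the scatter) removed the entire 1-(cyclopropylmethyl)pyrrolidin-3-yl group at this spot without moving the number, a methyl there is expected to do no more, and the expected step is no change at the digits printed from compound 2 to compound 3 (within the scatter). Compound 3 is therefore estimated at 1 nM, expected to fall between 0.5 nM and 3 nM.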

Compound 3, half-maximal inhibitory concentration: 4 nM
Compound 3: middle estimate off by 4.0-fold (0.60 log units), on the low side, outside the stated range (above it).
By their numbers in this assay, from the lowest: compounds 1 and 2 (each within the scatter of the next); then compound 3.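

In this assay this amide-type nitrogen turns out not to be indifferent to what it carries: swapping the amide hydrogen for a single methyl gives a 4.0-fold higher number from compound 2 to compound 3 (0.60 log units; beyond the scatter) and so registers as a modest change. The much larger 1-(cyclopropylmethyl)pyrrolidin-3-yl group does not share this penalty, since replacing it with methyl gives a 4.0-fold higher number from compound 1 to compound 3 (0.60 log units; beyond the scatter), so across these three compounds the read-out does not climb with the amount of group attached, which compound 1 and compound 2 alone could not reveal. No measurement available here accounts for this difference.

On these data alone, it remains open whether an ethyl group or a longer propyl chain would read like the methyl or like the pyrrolidine group. A simple chain ending in an amine would test whether the pyrrolidine ring is needed at all.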